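This account rests on a few compounds, and the source may have more. Where it says the series, first, only, none or still open, it means among the compounds named here.

Measured so far:
compound 1, `N=C(NCCC(O)c1ccccc1N)c1ccccc1`: 64.1%
compound 2, `N=C(NCCC(O)c1ccccc1N)c1ccc(Cl)cc1`: 73.2%
compound 3, `COc1ccc(N)c(C(O)CCNC(=N)c2ccccc2)c1`: 95.9%

In an assay for inhibition of Nitric oxide synthase, inducible (Homo sapiens), with a stated time of 30 min, tested at 1 mM (a higher number here means more inhibition at the concentration tested (going by the name of the read-out), a lower number less inhibition), compound 3 holds the highest of the three numbers. The change chloro in place of hydrogen on an aromatic carbon gave the step of a number 9.1 percentage points higher from compound 1 to compound 2 (within the scatter). The cores of compound 1 and compound 3 differ by methoxy in place of hydrogen on an aromatic carbon, which gave the step of a number 31.8 percentage points higher from compound 1 to compound 3 (beyond the scatter).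

Compound 4, `COc1ccc(N)c(C(O)CCNC(=N)c2ccc(Cl)cc2)c1`, has not been measured. It carries the change chloro in place of hydrogen on an aromatic carbon on the core of compound 3; the place is worded the same as for compound 2, so the change is the same, now made on the core of compound 3.

A smaller step than the earlier one is expected in this assay, because compound 3 already gives 95.9% and little room is left. The expected step is a number 1.1 percentage points higher from compound 3 to compound 4 (within the scatter), within the scatter. Compound 4 is estimated at 97%, with a range from 89% to 100%.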

Compound 4, a percentage reported as inhibition, at one concentration (the size of the read-out at that concentration, not a potency): 81%
Estimate against measurement, compound 4: 16 percentage points above; the measured number lies below the stated range.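

In this assay the change from phenyl to 4-chlorophenyl does not carry over from the core of compound 1 to the core of compound 3, where it gives a number 14.9 percentage points lower from compound 3 to compound 4 (beyond the scatter): the same change on two cores in this assay, a number 9.1 percentage points higher (within the scatter) from compound 1 to compound 2 and a number 14.9 percentage points lower (beyond the scatter) from compound 3 to compound 4, 24 percentage points apart, beyond the scatter of two such steps. The methoxy change also carries over poorly to the chloro-bearing core, with a number 7.8 percentage points higher from compound 2 to compound 4 (within the scatter): the same change on two cores in this assay, a number 31.8 percentage points higher (beyond the scatter) from compound 1 to compound 3 and a number 7.8 percentage points higher (within the scatter) from compound 2 to compound 4, 24 percentage points apart, beyond the scatter of two such steps. The two changes therefore do not add up across these four compounds, but this does not show why, or how either change would behave on any other core.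

On these data alone, it remains open how a fluoro group or a nitrile in place of the chloro would behave on these two cores. As far as these compounds go, the effect of a longer chain in place of the present one also remains open.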